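The source may report more compounds than this note shows. Statements on the series, on what has been measured and on what is new or still open speak of the compounds shown alone.

Measured in a functional assay on MGC-803 cells (Homo sapiens) for cytotoxicity, read by MTT assay, with a stated time of 72 h; on this read-out higher numbers stand for weaker inhibition and lower numbers for stronger inhibition:

- compound 1 `C=C1C(=O)[C@@]23C(=O)OC[C@]4(C(=O)CCC(C)(C)[C@H]4C=O)[C@@H]2CC[C@@H]1[C@H]3OC(C)=O`: 1660 nM
- compound 2 `C=C1C(=O)[C@@]23C(=O)OC[C@]4(C(=O)CCC(C)(C)[C@H]4C=O)[C@@H]2CC[C@@H]1[C@H]3OC(=O)CC`: 1780 nM
- compound 3 `C=C1C(=O)[C@@]23C(=O)OC[C@]4(C(=O)CCC(C)(C)[C@H]4C=O)[C@@H]2CC[C@@H]1[C@H]3OC(=O)c1ccc(OC)cc1`: 1870 nM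

Compound 2 stands in a tight group with the other two compounds, and no real difference separates the three. The next compound to test, compound 4 `C=C1C(=O)[C@@]23C(=O)OC[C@]4(C(=O)CCC(C)(C)[C@H]4C=O)[C@@H]2CC[C@@H]1[C@H]3OC(=O)c1ccc(C(F)(F)F)cc1`, carries 4-(trifluoromethyl)phenyl in place of ethyl on a carbonyl carbon.

Among the measured compounds shown here, the closest precedent is the swap of ethyl for 4-methoxyphenyl at the same carbonyl carbon, which gave a 1.1-fold higher number from compound 2 to compound 3 (0.02 log units; within the scatter). The exchange of methyl for 4-methoxyphenyl gave a 1.1-fold higher number from compound 1 to compound 3 (0.05 log units; within the scatter), and adding a methyl to the chain gave a 1.1-fold higher number from compound 1 to compound 2 (0.03 log units; within the scatter). Each of these changes left the number essentially where it was, although three compounds are a small sample and none of them carries trifluoromethyl. No step beyond the scatter is therefore expected in this assay, and the expected change is a 1.0-fold lower number from compound 2 to compound 4 (0.01 log units; within the scatter). For compound 4 the estimated value is 1750 nM, with an expected range from 900 nM to 3400 nM.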

Compound 4, half-maximal inhibitory concentration: 4930 nM
Compound 4: middle estimate off by 2.8-fold (0.45 log units), on the low side; the whole stated range lies below it.
By their numbers in this assay, from the lowest: compounds 1, 2 and 3 (each within the scatter of the next); then compound 4.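

In this assay this carbonyl carbon no longer looks indifferent to its substituent: 4-(trifluoromethyl)phenyl in place of ethyl gave a 2.8-fold higher number from compound 2 to compound 4 (0.44 log units; beyond the scatter) and in place of methyl gave a 3.0-fold higher number from compound 1 to compound 4 (0.47 log units; beyond the scatter) after earlier swaps had stayed within the scatter. An aromatic ring alone is not enough to produce this shift, as compound 3 also carries one and stays grouped with compound 1 and compound 2, while trifluoromethyl in place of methoxy on an aromatic carbon gave a 2.6-fold higher number from compound 3 to compound 4 (0.42 log units; beyond the scatter) and so ties the shift to the group on the ring. Nothing available explains why this group weakens the read-out.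

The compounds shown leave open whether a chlorine atom or a nitrile on the ring would act like trifluoromethyl or like methoxy. They also leave open where an unsubstituted phenyl would fall, and whether an amine on a longer chain would be tolerated on this carbonyl carbon.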